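This account rests on a few compounds, and the source may have more. Where it says the series, first, only, none or still open, it means among the compounds named here.

In an assay for inhibition of solute carrier family 22 member 12 (Homo sapiens), read by scintillation counting, with a stated time of 60 min, tested at 50 uM (on this read-out higher numbers stand for more inhibition at the one concentration tested (going by the name of the read-out) and lower numbers for less inhibition), two compounds of one series have been measured. Compound 1, with the structure `CCc1cc2c(C(=O)c3ccc(OC)cc3)c(O)ccc2o1`, gives 28.7% in this assay. Compound 2, with the structure `CCc1oc2cc(OC)ccc2c1C(=O)c1ccc(O)cc1`, gives 92.7% in this assay, and it stands highest of the two numbers: compound 1 lies a long way lower, a gap that exceeds the usual scatter of such measurements. Among the measured compounds shown here, no pair of measured compounds differs in one place only, so no single structural step has yet been tied to a change in the read-out.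

Compound 3, with the structure `CCc1oc2cc(O)ccc2c1C(=O)c1ccc(O)cc1`, has not been measured in this assay. It differs from compound 2 by hydrogen in place of methyl on an oxygen on an aromatic ring. For the measured compounds named here, since no measured step isolates this change, the expectation rests on compound 2 alone, which already gives 92.7% in this assay. The step from compound 2 to compound 3 is expected to be small, downward if anything, at a number 6.7 percentage points lower from compound 2 to compound 3 (within the scatter), within the scatter. Compound 3 is therefore estimated to give 86% in this assay, in a range from 60% to 98%.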

Compound 3, a percentage reported as inhibition, at one concentration (the size of the read-out at that concentration, not a potency): 92.1%
Compound 3: the middle estimate sits 6.1 percentage points below what was measured; the range from low to high includes it.
By their numbers in this assay, from the lowest: compound 1; then compounds 3 and 2 (each within the scatter of the next).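

In this assay, among the compounds shown here, the exchange of methoxy to hydroxy gives the first step that can be read in one place: a number 0.6 percentage points lower from compound 2 to compound 3 (within the scatter). On an oxygen on an aromatic ring, then, hydrogen can stand in place of methyl with no change in the read-out beyond the scatter, and in this pair the high inhibition at the one concentration tested does not depend on that methyl. Nothing measured alongside these numbers speaks to why the two compounds read alike.

Methoxy and hydroxy are the only groups compared at this place, so the compounds shown do not tell whether an ethoxy group, a longer chain ending in a carboxylic acid, or an amine in place of the oxygen would keep the read-out where it stands. As far as these compounds go, compound 1 still differs from compound 2 and compound 3 in more than one place, and because each compound was tested at a single concentration, any difference in potency between compound 2 and compound 3 also stays open.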